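Benzyl for Phenyl on the Ring Nitrogen: Cytotoxicity Notes

A few compounds are considered here, and "the series" means these few. Any claim that something is new, unique, unknown or untested is made for them only; others in the source may bear on it.

Two members of the series have been run in an ADME assay on HCT-116 cells (Homo sapiens) for cytotoxicity, read by MTT assay, with a stated time of 72 h; a lower number here means a stronger inhibitor, a higher number a weaker inhibitor. Compound 1 `CCc1cccc(NC(=O)c2cccc(/C=C3\CC(=O)N(Cc4ccccc4)C3=O)c2)c1` gives 80600 nM in this assay. Compound 2 `O=C(Nc1ccc(Cl)cc1)c1cccc(/C=C2\CC(=O)N(c3ccccc3)C2=O)c1` returns only a limit of the method in this assay, > 100000 nM, and no number stands for compound 2. Among the measured compounds shown here, the two measured compounds do not differ in a single place, so no measured step between them is available; what the data offer is the limit of > 100000 nM in this assay, at which 1 of the 2 values shown sits. Compound 3 `O=C(Nc1ccc(Cl)cc1)c1cccc(/C=C2\CC(=O)N(Cc3ccccc3)C2=O)c1` is not yet measured; it differs from compound 2 by benzyl in place of phenyl on an amide-type nitrogen in a ring. The same benzyl on the amide-type nitrogen in the ring is carried by compound 1, whose reading in this assay, 80600 nM, is a measured value rather than a limit. On that basis compound 3 is expected to land around 75000 nM, with a range from 35000 nM to 150000 nM. The step of an at least 1.3-fold lower number from compound 2 to compound 3 (0.12 log units; that floor lies within the scatter) is expected to run from a limit into measurable territory, in the direction of stronger inhibition, though a second limit read-out for compound 3 cannot be excluded.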

Compound 3, half-maximal inhibitory concentration: > 100000 nM
Compound 3 gave a limit, no number; the forecaster's own chance of this, stated with the estimate: 35%; middle value at least 1.3-fold (0.12 log units) from the limit.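

Compound 3 reads > 100000 nM in this assay, a limit and not a number, so benzyl on the amide-type nitrogen in the ring does not by itself give this 4-chlorophenyl amide a measured value. Both ends of the change from phenyl to benzyl are limits, so that step cannot be read, and neither a gain nor a loss can be assigned to this position. The change of 4-chlorophenyl in place of 3-ethylphenyl on the amide-type nitrogen, with benzyl held constant, gives an at least 1.2-fold higher number from compound 1 to compound 3 (0.09 log units; that floor lies within the scatter), a floor that does not separate the pair, leaving the effect of that change unresolved.

Most of the readings so far sit at the end of what the method can report: the limit of > 100000 nM in this assay, at which 2 of the 3 values shown sit. Going by these compounds, whether an amine or a carboxylic acid on the benzyl group, or a longer chain such as phenethyl on the amide-type nitrogen in the ring, would bring a reading clear of this limit remains open.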